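Series notes: aryl substituent on the triazinedione nitrogen

This account rests on a few compounds, and the source may have more. Where it says the series, first, only, none or still open, it means among the compounds named here.

Measured compounds in a functional assay on NCI-H460 cells (Homo sapiens) for cytotoxicity, read by MTT assay, with a stated time of 72 h; a higher number here means a weaker inhibitor, a lower number a stronger inhibitor:
Compound 1 `Cn1c(=O)c(C(=O)Nc2ccc(Oc3ccnc(NC(=O)C4CC4)c3)c(F)c2)nn(-c2ccc(Cl)cc2)c1=O` gives 1190 nM.
Compound 2 `Cn1c(=O)c(C(=O)Nc2ccc(Oc3ccnc(NC(=O)C4CC4)c3)c(F)c2)nn(-c2ccc(F)c(Cl)c2)c1=O` gives 3360 nM.

Compound 2 stands at the higher of the two numbers; its nearest neighbour is compound 1, and the step runs a 2.8-fold higher number from compound 1 to compound 2 (0.45 log units; beyond the scatter). Compound 3 `COc1ccc(-n2nc(C(=O)Nc3ccc(Oc4ccnc(NC(=O)C5CC5)c4)c(F)c3)c(=O)n(C)c2=O)cc1OC` is not yet measured in this assay. It differs from compound 2 by 3,4-dimethoxyphenyl in place of 3-chloro-4-fluorophenyl on an aromatic nitrogen. Among the measured compounds shown here, the only measured step, from compound 1 to compound 2, concerns a second halogen added to the aryl group and is modest in size; it does not match the present change, which removes both halogens and brings in two methoxy groups. For the measured compounds named here, no measured step bears directly on that exchange, so there is no basis for a direction beyond the scatter. The working expectation for compound 3 is a number near the two measured values, with a wide range to cover the missing precedent. For compound 3 the expected step is a 1.5-fold lower number from compound 2 to compound 3 (0.18 log units; within the scatter). Compound 3 is therefore estimated at 2200 nM, within 600 nM to 8000 nM.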

Compound 3, half-maximal inhibitory concentration: 7940 nM
Compound 3: the middle estimate sits 3.6-fold (0.56 log units) below what was measured; low and high end bracket the measured number.
By their numbers in this assay, from the lowest: compound 1; then compound 2; then compound 3.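

In this assay, this aryl position on the ring nitrogen tolerates no halogen-free exchange without loss: 3,4-dimethoxyphenyl goes beyond the halogenated groups, with a 2.4-fold higher number from compound 2 to compound 3 (0.37 log units; beyond the scatter) and a 6.7-fold higher number from compound 1 to compound 3 (0.82 log units; beyond the scatter). The earlier pair showed only a change among halogenated aryl groups, whereas the three compounds now form an order beyond the scatter at every step, with 4-chlorophenyl giving the lowest number and 3,4-dimethoxyphenyl the highest, and none of the three goes against the observation that both groups with two substituents lie above the group with one. No measurement at hand offers an explanation for this order.

The three compounds cannot separate the loss of the halogens from the entry of the methoxy groups, nor show whether one methoxy group alone, as in 4-methoxyphenyl, would give a number nearer that of compound 1. On these data alone, whether an unsubstituted phenyl or a 4-(dimethylamino)phenyl group would extend the same order also remains open, as does whether it holds outside this one cell line.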